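The source may report more compounds than this note shows. Statements on the series, on what has been measured and on what is new or still open speak of the compounds shown alone.

Compound 1 `CCC1(CCCCN2CC=C(c3ccc(Cl)cc3)CC2)C(=O)Nc2ccccc21`: > 20 mg/kg
Compound 2 `CC(C)CC1(CCCCN2CCN(c3cccc(Cl)c3)CC2)C(=O)Nc2ccccc21`: 10 mg/kg
Compound 3 `CCC1(CCCCN2CCN(c3ccc(OC)cc3)CC2)C(=O)Nc2ccccc21`: > 20 mg/kg

In a functional assay on the whole organism (strain Wistar) with Rattus norvegicus as the target, with a stated time of 5 min (a lower number here means that less compound is needed, a higher number that more compound is needed for the effect), compound 3 reaches only a limit of the test, > 20 mg/kg. Compound 1 likewise gives only a limit, > 20 mg/kg. Compound 2 gives a number, 10 mg/kg. So compound 3 stands at the limit of > 20 mg/kg in this assay, at which 2 of the 3 values shown sit, and no number places it more exactly. Compound 4 `CCC1(CCCCN2CCN(c3ccccc3)CC2)C(=O)Nc2ccccc21` is made from compound 3 by one change: hydrogen in place of methoxy on an aromatic carbon. Among the compounds with values here, no measured pair in this set shows that change on its own, so its size and direction are open. Compound 4 is expected to sit near compound 3, with a step of an at least 1.3-fold lower number from compound 3 to compound 4 (0.12 log units; that floor lies within the scatter) that may well stay within the scatter. Compound 4 is therefore estimated at 15 mg/kg, between 5 mg/kg and 40 mg/kg.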

Compound 4, minimum effective dose: 10 mg/kg
The estimate for compound 4 lay 1.5-fold (0.18 log units) above the measured number, and the stated range covers the measured number.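

Going from 4-methoxyphenyl to phenyl gives the only measured step at this position in this assay: an at least 2.0-fold lower number from compound 3 to compound 4 (0.30 log units; that floor lies within the scatter). With hydrogen at this place, para to a large group, the assay returns a number rather than a limit. The true size of the step stays unknown, because compound 3 sits at a limit: the limit of > 20 mg/kg in this assay, at which 2 of the 4 values shown sit.

The compounds shown leave open how other groups at this place, such as an amine, a carboxylic acid or a longer chain, would compare with hydrogen. They also leave open whether the step would hold on another core.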